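Cyclohexyl in place of 1-phenylethyl on the ring amine

The source may report more compounds than this note shows. Statements on the series, on what has been measured and on what is new or still open speak of the compounds shown alone.

For the measured compounds named here, the series so far holds two measured compounds. Compound 1 `CCCCCNc1oc2c(C)ncc(CO)c2c1Nc1ccccn1` gives 5810 nM in a functional assay on HEK293 cells for agonist activity at Toll-like receptor 8 (Homo sapiens), read by reporter gene assay; on this read-out lower numbers stand for an effect already at smaller amounts and higher numbers for an effect only at larger amounts of compound. Compound 2 `Cc1ncc(CO)c2c(Nc3ccccn3)c(N[C@@H](C)c3ccccc3)oc12` gives 4270 nM in this assay. Going by the values given here, the one change between them, 1-phenylethyl in place of pentyl on a nitrogen on an aromatic ring, brings a 1.4-fold lower number from compound 1 to compound 2 (0.13 log units; within the scatter). On the two numbers shown, compound 2 and compound 1 thus stand within the scatter of each other, and neither can be called the more potent.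

Compound 3 `Cc1ncc(CO)c2c(Nc3ccccn3)c(NC3CCCCC3)oc12` is not yet measured. It differs from compound 2 in one place: cyclohexyl in place of 1-phenylethyl on a nitrogen on an aromatic ring. Among the compounds with values here, no measured step introduces a cyclohexyl on this nitrogen, so the only step that bears on it is the one from compound 1 to compound 2, where a chain was traded for a substituted aromatic ring on the same nitrogen. That swap left the number within the scatter; no step beyond the scatter is expected here either, in either direction. Compound 3 is therefore estimated at 4500 nM, with a range of 1800 nM to 11000 nM, which corresponds to an expected step of a 1.1-fold higher number from compound 2 to compound 3 (0.02 log units; within the scatter).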

Compound 3, half-maximal effective concentration: 6930 nM
Compound 3: the middle estimate sits 1.5-fold (0.19 log units) below what was measured; the range from low to high includes it.
By their numbers in this assay, from the lowest: compounds 2, 1 and 3 (each within the scatter of the next).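

On the nitrogen on an aromatic ring, cyclohexyl in place of 1-phenylethyl leaves the reading in this assay within the scatter (a 1.6-fold higher number from compound 2 to compound 3 (0.21 log units; within the scatter)), and cyclohexyl in place of pentyl does the same (a 1.2-fold higher number from compound 1 to compound 3 (0.08 log units; within the scatter)). A non-aromatic ring of carbon only thus reads alike with both the open chain and the group carrying an aromatic ring, so across these three compounds an aromatic ring in this substituent is not required for a reading at this level, nor is the defined stereocentre of 1-phenylethyl. No measurement at hand accounts for this flat reading.

All three substituents shown are built of carbon only, so it stays open whether any change at this nitrogen can move the number beyond the scatter. A substituent carrying an amine or a carboxylic acid, a longer chain, a small group such as methyl, or the opposite stereocentre of 1-phenylethyl would test the limits of this flat reading.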